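The source may report more compounds than this note shows. Statements on the series, on what has been measured and on what is new or still open speak of the compounds shown alone.

Two relatives share one core and differ only in the group on an amide-type nitrogen. In an in vitro ADME assay on microsomes from liver (Mus musculus) for pharmacokinetics, read by LC-MS, with a stated time of 10 min, tested at 1 uM (on this read-out lower numbers stand for slow clearance and higher numbers for fast clearance), compound 2 `CN1C[C@H](C(=O)Nc2ccccc2F)[C@@H](c2ccc(/C=C/C(=O)Nc3ccccc3N)cc2)C1` gives 67 mL/min/kg and compound 1 `CN1C[C@H](C(=O)Nc2ccc(C#N)cc2)[C@@H](c2ccc(/C=C/C(=O)Nc3ccccc3N)cc2)C1` gives 35 mL/min/kg, so these two numbers stand within the usual scatter of each other.

The next compound, compound 3 `CN1C[C@H](C(=O)Nc2ccc(F)c(F)c2)[C@@H](c2ccc(/C=C/C(=O)Nc3ccccc3N)cc2)C1`, keeps the core and alters that same group: 3,4-difluorophenyl in place of 2-fluorophenyl on an amide-type nitrogen. In words, 3,4-difluorophenyl takes the place of 2-fluorophenyl on an amide-type nitrogen, whose other neighbour is a carbonyl carbon.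

Within the data shown here, only one measured step bears on this. It is a 1.9-fold higher number from compound 1 to compound 2 (0.28 log units; within the scatter), with 2-fluorophenyl in place of 4-cyanophenyl at the same nitrogen, and it stays within the scatter. Among the measured compounds shown here, no measured compound carries 3,4-difluorophenyl, so the data offer no direction for the new group. For the measured compounds named here, with that single step as the only guide, no change beyond the scatter is expected in this assay. The estimated step is a 1.3-fold lower number from compound 2 to compound 3 (0.13 log units; within the scatter). For compound 3 the expected clearance is about 50 mL/min/kg, with an estimated range from 25 mL/min/kg to 100 mL/min/kg.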

Compound 3, clearance: 46 mL/min/kg
Compound 3: the middle estimate sits 1.1-fold (0.04 log units) above what was measured; the range from low to high includes it.
By their numbers in this assay, from the lowest: compounds 1, 3 and 2 (each within the scatter of the next).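

In this assay, a third substituted phenyl group on this amide-type nitrogen gives a result that cannot be told apart from the first two: putting 3,4-difluorophenyl in place of 2-fluorophenyl gives a 1.5-fold lower number from compound 2 to compound 3 (0.16 log units; within the scatter), and putting it in place of 4-cyanophenyl gives a 1.3-fold higher number from compound 1 to compound 3 (0.12 log units; within the scatter). All three pairs among compounds 1, 2 and 3 now lie within the scatter, so at this position neither the swap from a nitrile to fluorine nor the swap from one fluorine to two separates one compound from another in this read-out, which one step alone could not show. No supporting measurement is available to explain why these numbers lie so close together.

The groups shown on this nitrogen are all phenyl rings carrying nitrile or fluorine, so it remains open whether a different kind of group here, such as a longer alkyl chain or a phenyl ring bearing an amine or a carboxylic acid, would shift clearance beyond the scatter. As far as these compounds go, all three compounds also share the same core, and whether this pattern would hold on a changed core remains open too.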